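From formyl to (pyrrolidin-1-yl)methyl on the shared core

This account rests on a few compounds, and the source may have more. Where it says the series, first, only, none or still open, it means among the compounds named here.

Growth inhibition was measured in a functional assay on MV4-11 cells (Homo sapiens) for inhibition, read by resazurin assay, with a stated time of 72 h (a higher number here means a weaker inhibitor of growth, a lower number a stronger inhibitor of growth), for two compounds:

- compound 1 `O=C1NCCC12CCN(c1c(Cl)cncc1-c1cccs1)CC2` gives 480 nM
- compound 2 `O=Cc1ccc(-c2cncc(Cl)c2N2CCC3(CCNC3=O)CC2)s1` gives 750 nM

For the measured compounds named here, with only these two values available, compound 2 (750 nM) stands within the scatter of compound 1, its sole neighbour. The next compound, compound 3 `O=C1NCCC12CCN(c1c(Cl)cncc1-c1ccc(CN3CCCC3)s1)CC2`, has yet to be measured. It carries (pyrrolidin-1-yl)methyl in place of formyl on an aromatic carbon on the same core.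

Going by the values given here, one measured step bears on this change. It is a 1.6-fold higher number from compound 1 to compound 2 (0.19 log units; within the scatter) and replaces hydrogen with formyl on an aromatic carbon. That step stays within the scatter, so the one substitution seen so far at this carbon left the number essentially unmoved. Among the compounds with values here, no measured compound carries the incoming group, however, so the data cannot speak to it directly, and the range must stay wide.

The expected step is a 1.7-fold lower number from compound 2 to compound 3 (0.22 log units; within the scatter) in this assay and is not expected to exceed the scatter. For compound 3 the estimated value is 450 nM (expected range 150 nM to 1300 nM).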

Compound 3, concentration for 50% growth inhibition: 3370 nM
Compound 3: the middle estimate sits 7.5-fold (0.87 log units) below what was measured; the measured number lies above the stated range.
By their numbers in this assay, from the lowest: compounds 1 and 2 (each within the scatter of the next); then compound 3.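

At this aromatic carbon, next to the ring sulfur, the number proves to depend on the group placed there: in this assay, the change to (pyrrolidin-1-yl)methyl gives a 4.5-fold higher number from compound 2 to compound 3 (0.65 log units; beyond the scatter), and the comparison with hydrogen at the same carbon gives a 7.0-fold higher number from compound 1 to compound 3 (0.85 log units; beyond the scatter). For the compounds shown here, both steps lie beyond the scatter, whereas the only earlier step at this carbon, a 1.6-fold higher number from compound 1 to compound 2 (0.19 log units; within the scatter), lay within it, so the position is not indifferent to substitution, as those first two compounds alone might have suggested, and compound 3 is the weakest inhibitor of growth of the three. No evidence is available to explain this loss.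

The compounds shown leave open whether the loss follows from the amine nitrogen, from the pyrrolidine ring or simply from a larger group at this carbon, since (pyrrolidin-1-yl)methyl brings all of these at once. A dimethylaminomethyl group, a morpholin-4-ylmethyl group, a hydroxymethyl group or a carboxylic acid at the same carbon would begin to separate these possibilities, and nothing shown says how any of them would read in this assay.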